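Dichlorophenyl piperazine amide: expected electroshock dose

A few compounds are considered here, and "the series" means these few. Any claim that something is new, unique, unknown or untested is made for them only; others in the source may bear on it.

Measured compounds:
compound 1 `CC1(c2ccccc2)CC(=O)N(CC(=O)N2CCN(c3ccccc3)CC2)C1=O`, in a functional assay on the whole organism (strain CD-1) with Mus musculus as the target, in the maximal electroshock model, with a stated time of 0.5 h (on this read-out higher numbers stand for an effect only at larger amounts of compound and lower numbers for an effect already at smaller amounts), compound 1 gives 300 mg/kg
compound 2 `CC1(c2ccccc2)CC(=O)N(CC(=O)N2CCN(c3ccccc3Cl)CC2)C1=O`, in this assay compound 2 gives "not active" (no number reported)

Within the data shown here, compound 2 stands without a number on the read-out: compound 2 is recorded only as not active, so no dose can be placed beside it and no step between compound 1 and compound 2 can be counted. All that the two values show is that compound 1 reaches a dose on the read-out while compound 2 does not.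

The unmeasured compound 3 `CC1(c2ccccc2)CC(=O)N(CC(=O)N2CCN(c3cccc(Cl)c3Cl)CC2)C1=O` differs from compound 2 by one change: chloro in place of hydrogen on an aromatic carbon. Cut one bond further out the change reads 2-chlorophenyl to 2,3-dichlorophenyl.

With compound 2 giving no number, no step size can be set out for compound 3 in this assay; the direction is open, and the expectation rests only on compound 2 lying outside the measurable range. Compound 3 is therefore expected to lie at a high dose, around 400 mg/kg, within 150 mg/kg to 1000 mg/kg, with a considerable chance that only a limit and no number is reported.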

Compound 3, minimum effective dose: "not active" (no number reported)
Nothing numeric was reported for compound 3; no gap can be computed for the estimate.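

In this assay compound 2 and compound 3 are both recorded as not active, without a number, so no step can be read between them. The compounds shown leave open whether chloro in place of hydrogen shifts the dose at all. No measurement shown bears on this result.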